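A few compounds are considered here, and "the series" means these few. Any claim that something is new, unique, unknown or untested is made for them only; others in the source may bear on it.

Measured so far in an assay on isolated protein (strain Sprague-Dawley) for inhibition of Amine oxidase [flavin-containing] B (Rattus norvegicus), read by spectrophotometry, with a stated time of 5 min; on this read-out lower numbers stand for stronger inhibition and higher numbers for weaker inhibition:

compound 1 `O=C(COc1cc(=O)oc2cc(OCc3cccc(Cl)c3)ccc12)N1CCCCC1`: 38900 nM
compound 2 `Nc1cc(=O)oc2cc(OCc3cccc(Cl)c3)ccc12`: 47.9 nM
compound 3 `CCNc1cc(=O)oc2cc(OCc3cccc(Cl)c3)ccc12`: 28.2 nM

Compound 3 has the lowest number of the three. Against compound 2 the step is a 1.7-fold lower number from compound 2 to compound 3 (0.23 log units; within the scatter), within the scatter, so the two cannot be ordered. Against compound 1 the step is a 1400-fold lower number from compound 1 to compound 3 (3.14 log units; beyond the scatter); compound 2 also stands far from compound 1, an 810-fold lower number from compound 1 to compound 2 (2.91 log units; beyond the scatter).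

Compound 4 `O=Cc1cc(=O)oc2cc(OCc3cccc(Cl)c3)ccc12` has not yet been measured in this assay. The change from compound 3 is formyl in place of ethylamino on an aromatic carbon. Among the compounds with values here, no measured step removes the nitrogen at this place, so the bearing of the three measured steps is indirect. The two large steps replace the ((piperidin-1-yl)carbonyl)methoxy group by amino or by ethylamino and show that a small substituent here goes with low numbers; the step from compound 2 to compound 3 shows that ethyl on the nitrogen changes little. Formyl is another small substituent, so a return to the number of compound 1 is not expected, but the exchange of a donor-bearing group for one with none has no precedent in the series, and a moderate rise is estimated, an 11-fold higher number from compound 3 to compound 4 (1.03 log units; beyond the scatter). Compound 4 is estimated at 300 nM, with a range from 50 nM to 3000 nM.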

Compound 4, half-maximal inhibitory concentration: 52.5 nM
Beside the measured number, compound 4's estimate is 5.7-fold (0.76 log units) above it, and the stated range covers the measured number.
By their numbers in this assay, from the lowest: compounds 3, 2 and 4 (each within the scatter of the next); then compound 1.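

In this assay formyl, on the aromatic carbon opposite the ring oxygen, cannot be told apart from either nitrogen group: a 1.9-fold higher number from compound 3 to compound 4 (0.27 log units; within the scatter) and a 1.1-fold higher number from compound 2 to compound 4 (0.04 log units; within the scatter) both leave compound 4 level with the amines. Neither a nitrogen on this carbon nor a hydrogen-bond donor is therefore required for a number in this range, as formyl has 0 hydrogen-bond donors and still matches amino and ethylamino, a point the comparison of compound 2 with compound 3 could not show. The large gap to the ((piperidin-1-yl)carbonyl)methoxy group now holds for a third small substituent and one of a different kind, with a 740-fold lower number from compound 1 to compound 4 (2.87 log units; beyond the scatter) as its measure, and no measurement shown accounts for either the level numbers or this gap.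

The compounds shown leave open how far the number rises between formyl and the ((piperidin-1-yl)carbonyl)methoxy group, which a methoxy group, a carboxylic acid or a longer alkyl chain on the same carbon could begin to map. From the compounds shown here alone, it also remains open whether the piperidine amide or the ether oxygen of that group goes with the high number of compound 1.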